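Swapping the pyrazole for a fluoropyridine on a thiazole acid

The source may hold more compounds than are shown below. What is called first, only, known or untested is meant among the compounds shown, and "the series" means these compounds.

Three compounds share one core and differ only in the aromatic group attached to it. In an in vitro functional assay on HEK285-7 cells for antagonist activity at prostaglandin D2 receptor 2 (Homo sapiens), read by BRET and beta-arrestin recruitment (on this read-out higher numbers stand for weaker inhibition and lower numbers for stronger inhibition), compound 1 `O=C(O)Cc1sc(C(c2ccc(F)cc2)c2ccc(F)cc2)nc1-c1ccc(Cl)cc1` gives 180 nM, compound 2 `N#Cc1cc(-c2nc(C(c3ccc(F)cc3)c3ccc(F)cc3)sc2CC(=O)O)ccc1F` gives 520 nM, and compound 3 `O=C(O)Cc1sc(C(c2ccc(F)cc2)c2ccc(F)cc2)nc1-c1cn[nH]c1` gives 220 nM. Compound 3 therefore stands second highest of the three, close to compound 1 and further from compound 2.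

Compound 4 `O=C(O)Cc1sc(C(c2ccc(F)cc2)c2ccc(F)cc2)nc1-c1ccnc(F)c1` differs from compound 3 in one place: 2-fluoropyridin-4-yl in place of 1H-pyrazol-4-yl on an aromatic carbon. The measured steps at this same position are a 1.2-fold higher number from compound 1 to compound 3 (0.09 log units; within the scatter), a 2.9-fold higher number from compound 1 to compound 2 (0.46 log units; beyond the scatter) and a 2.4-fold lower number from compound 2 to compound 3 (0.37 log units; beyond the scatter). Changes of the aromatic group here have so far kept the number within a narrow band in either direction, and the six-membered rings of compound 1 and compound 2 bracket compound 3 on both sides. The step of a 1.4-fold higher number from compound 3 to compound 4 (0.13 log units; within the scatter) is therefore expected to be small, most likely a slight rise. Compound 4 is estimated to give 300 nM in this assay, within a range from 120 nM to 750 nM.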

Compound 4, half-maximal inhibitory concentration: 4.7 nM
Estimate against measurement, compound 4: 64-fold (1.81 log units) above; the whole stated range lies above it.
By their numbers in this assay, from the lowest: compound 4; then compounds 1 and 3 (each within the scatter of the next); then compound 2.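

In this assay, among these compounds, this position proves far more sensitive than the earlier compounds suggested: 2-fluoropyridin-4-yl in place of 1H-pyrazol-4-yl gives a large gain (a 47-fold lower number from compound 3 to compound 4 (1.67 log units; beyond the scatter)), where the earlier groups spanned only a modest spread. The same group also stands well apart from the other two (a 38-fold lower number from compound 1 to compound 4 (1.58 log units; beyond the scatter) and a 110-fold lower number from compound 2 to compound 4 (2.04 log units; beyond the scatter)), so compound 4 is the strongest of the four, with every step to it beyond the scatter. A six-membered aromatic ring alone is not enough, since compound 1 and compound 2 carry one too and neither comes close to compound 4.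

No measurement here explains this jump. The compounds shown leave open whether the gain needs the fluorine, the ring nitrogen or both, a question that plain pyridin-4-yl and 2-chloropyridin-4-yl at this position could help to separate.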